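Tert-Butyl Amide on the Shared Core of Compound 1

The source may hold more compounds than are shown below. What is called first, only, known or untested is meant among the compounds shown, and "the series" means these compounds.

Among the measured compounds shown here, compound 1 `CC(O)C(=O)Nc1cc(Oc2ccc(Nc3nccc4[nH]cc(-c5ccc(F)cc5)c(=O)c34)cc2F)ccn1` has the higher number of the two compounds measured so far. In a functional assay on MKN-45 cells (Homo sapiens) for antiproliferative activity, read by MTT assay, with a stated time of 72 h, tested at 10 uM (on this read-out lower numbers stand for less inhibition and higher numbers for more inhibition at the one concentration tested (going by the name of the read-out)), compound 1 gives 67.3%, while compound 2 `Cn1cc(-c2ccc(F)cc2)c(=O)c2c(Nc3ccc(Oc4ccnc(NC(=O)C5CC5)c4)c(F)c3)nccc21` gives 30.9% in this assay, a gap beyond the usual scatter. Compound 3 `CC(C)(C)C(=O)Nc1cc(Oc2ccc(Nc3nccc4[nH]cc(-c5ccc(F)cc5)c(=O)c34)cc2F)ccn1` differs from compound 1 only at the amide: tert-butyl in place of 1-hydroxyethyl on a carbonyl carbon. For the measured compounds named here, since no measured pair shows this exchange, the step of a number 9.3 percentage points lower from compound 1 to compound 3 (within the scatter) is only an expectation, and a modest drop in the number or none beyond the scatter seems most likely. Compound 3 is expected to give about 58% in this assay, within 38% to 78%.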

Compound 3, a percentage reported as inhibition, at one concentration (the size of the read-out at that concentration, not a potency): 62.5%
For compound 3 the middle estimate is 4.5 percentage points below the measured one; measured number inside the range.
By their numbers in this assay, from the lowest: compound 2; then compounds 3 and 1 (each within the scatter of the next).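

In this assay, tert-butyl in place of 1-hydroxyethyl on a carbonyl carbon gives a number 4.8 percentage points lower from compound 1 to compound 3 (within the scatter), so this position accepts the exchange without a change beyond the scatter. The two groups read alike here although 1-hydroxyethyl carries 1 hydrogen-bond donor and 1 hydrogen-bond acceptor and tert-butyl carries 0 of each. No measurement at hand gives a reason for this result.

From the compounds shown here alone, whether an amine, a carboxylic acid or a longer chain on this carbonyl carbon would keep the number at this level remains open.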